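This account rests on a few compounds, and the source may have more. Where it says the series, first, only, none or still open, it means among the compounds named here.

Measured in a functional assay on SiHa cells (Homo sapiens) for antiproliferative activity, read by CCK-8 assay, with a stated time of 72 h; on this read-out lower numbers stand for stronger inhibition and higher numbers for weaker inhibition:
- compound 1 `CCOc1ccc(-c2cncnc2-c2cc(OC)c(OC)c(OC)c2)cc1`: 640 nM
- compound 2 `COc1ccc(-c2cncnc2-c2cc(OC)c(OC)c(OC)c2)nc1`: 1750 nM
- compound 3 `COc1cc(-c2ncncc2-c2ccc(B(O)O)cc2)cc(OC)c1OC`: 17500 nM

Compound 3 has the highest number of the three. Compound 4 `COc1cc(-c2ncncc2-c2ccc3cc[nH]c3c2)cc(OC)c1OC` is still unmeasured. The change to it is a group of 9 heavy atoms (8 carbon, 1 nitrogen; one five-membered aromatic ring with 1 hetero atom, one six-membered aromatic ring of carbon only) in place of a group of 9 heavy atoms (6 carbon, 1 boron, 2 oxygen; one six-membered aromatic ring of carbon only), on an aromatic carbon, replacing that group with 1H-indol-6-yl.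

Two steps end at the group now leaving: a 27-fold higher number from compound 1 to compound 3 (1.44 log units; beyond the scatter), and a 10-fold higher number from compound 2 to compound 3 (1.00 log units; beyond the scatter). Both raise the number, while a 2.7-fold higher number from compound 1 to compound 2 (0.44 log units; beyond the scatter) is smaller. For the measured compounds named here, no measured compound carries 1H-indol-6-yl, so the reversal of those steps is only an expectation. A large drop is expected in this assay, to about the level of the other two compounds. The expected change is a 35-fold lower number from compound 3 to compound 4 (1.54 log units; beyond the scatter). The estimate for compound 4 is 500 nM, with an expected range of 80 nM to 3000 nM.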

Compound 4, half-maximal inhibitory concentration: 2180 nM
Beside the measured number, compound 4's estimate is 4.4-fold (0.64 log units) below it; measured number inside the range.
By their numbers in this assay, from the lowest: compound 1; then compounds 2 and 4 (each within the scatter of the next); then compound 3.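

In this assay, putting 1H-indol-6-yl at this position gives an 8.0-fold lower number from compound 3 to compound 4 (0.90 log units; beyond the scatter) and shows that a two-ring group is tolerated ortho to a large group. Set against 5-methoxypyridin-2-yl, it gives a 1.2-fold higher number from compound 2 to compound 4 (0.10 log units; within the scatter) and cannot be told apart from that group. 4-Ethoxyphenyl still holds the lowest number here, as a 3.4-fold higher number from compound 1 to compound 4 (0.53 log units; beyond the scatter) shows.

Going by these compounds, whether an amine or a carboxylic acid on the phenyl ring would match 4-ethoxyphenyl remains open. No measurement at hand explains any of these steps.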